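A few compounds are considered here, and "the series" means these few. Any claim that something is new, unique, unknown or untested is made for them only; others in the source may bear on it.

Three compounds have been measured in an assay on isolated protein with Bile acid receptor (Homo sapiens) as the target; on this read-out lower numbers stand for an effect already at smaller amounts and higher numbers for an effect only at larger amounts of compound:

Compound 1 `COC(=O)/C=C/c1cccc(N(Cc2ccc(/C=C/c3ccc(F)cc3)cc2)C(=O)C(C)C)c1` gives 120 nM.
Compound 2 `CCOC/C=C/c1cccc(N(Cc2ccc(/C=C/C(=O)OC(C)(C)C)cc2)C(=O)C2CCCCC2)c1` gives 220 nM.
Compound 3 `COC(=O)/C=C/c1cccc(N(Cc2ccc(/C=C/c3ccc(F)cc3)cc2)C(=O)C2CCCCC2)c1` gives 185 nM.

Compound 1 has the smallest of the three numbers, but the step of a 1.5-fold higher number from compound 1 to compound 3 (0.19 log units; within the scatter) lies within the usual scatter. The gap between compound 1 and compound 2 also lies within the usual scatter, so the three cannot be told apart.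

Compound 4 `COC(=O)/C=C/c1cccc(N(Cc2ccc(-c3ccc(F)c(Cl)c3)cc2)C(=O)C(C)C)c1` differs from compound 1 by 3-chloro-4-fluorophenyl in place of 2-(4-fluorophenyl)ethenyl on an aromatic carbon. Among the compounds with values here, the one measured step, a 1.5-fold higher number from compound 1 to compound 3 (0.19 log units; within the scatter), concerns the group on the carbonyl carbon and says nothing about this part of the molecule; no measured step bears on the present change. The expectation therefore rests on the structural change alone and carries a wide range. Compound 4 is expected to give 300 nM, with a range from 80 nM to 1500 nM. For compound 4 this estimate means an expected step of a 2.5-fold higher number from compound 1 to compound 4 (0.40 log units; beyond the scatter).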

Compound 4, half-maximal effective concentration: 129 nM
Beside the measured number, compound 4's estimate is 2.3-fold (0.37 log units) above it; the measured number falls inside the stated range.
By their numbers in this assay, from the lowest: compounds 1, 4, 3 and 2 (each within the scatter of the next).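

Replacing 2-(4-fluorophenyl)ethenyl with 3-chloro-4-fluorophenyl on the aromatic carbon gives in this assay a 1.1-fold higher number from compound 1 to compound 4 (0.03 log units; within the scatter) and so, within the scatter, this position keeps its reading without the double bond outside the aromatic rings. Within the data shown here, this is the first one-place step read at this position, as the earlier one concerned the group on the carbonyl carbon. Nothing available explains why the two groups read alike.

As far as these compounds go, how this position responds to a group without an aromatic ring, such as an amine or a carboxylic acid, remains open. From the compounds shown here alone, the separate contributions of the chlorine and the fluorine on the new ring also remain open.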